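From methyl to 1-aminocyclopentyl on a carbonyl carbon

The source may report more compounds than this note shows. Statements on the series, on what has been measured and on what is new or still open speak of the compounds shown alone.

- compound 1 `CC(=O)N1CCCc2c(C)c3c(n2-c2ccc(C(N)=O)c(c2)N[C@@H](C)[C@@H]1C)CC(C)(C)CC3=O` gives 29 nM
- compound 2 `CC(=O)N1CCc2c(C)c3c(n2-c2ccc(C(N)=O)c(c2)N[C@@H](C)[C@H](C)C1)CC(C)(C)CC3=O` gives 24 nM
- compound 3 `Cc1c2c(n3c1CCCN(C(=O)CO)[C@@H](C)[C@H](C)Nc1cc-3ccc1C(N)=O)CC(C)(C)CC2=O` gives 111 nM

All three numbers come from a functional assay on U-87MG ATCC cells (Homo sapiens) for antiproliferative activity (on this read-out higher numbers stand for weaker inhibition and lower numbers for stronger inhibition), and can be compared directly. Compound 2 sits at the low end of this small set. It lies within the scatter of compound 1, so those two cannot be ranked, while compound 3 has a clearly higher number than compound 2.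

The next compound, compound 4 `Cc1c2c(n3c1CCN(C(=O)C1(N)CCCC1)C[C@@H](C)[C@H](C)Nc1cc-3ccc1C(N)=O)CC(C)(C)CC2=O` keeps the core of compound 2 but carries 1-aminocyclopentyl in place of methyl on a carbonyl carbon. For the measured compounds named here, only one measured step touches this part of the molecule. It puts hydroxy in place of hydrogen on a saturated chain carbon bound to a carbonyl carbon, and it gave a 3.8-fold higher number from compound 1 to compound 3 (0.58 log units; beyond the scatter) as a modest rise. That step starts from compound 1 rather than compound 2, and its change is much smaller than the one here. Going by the values given here, no measured compound has an amino group or a ring on this carbonyl, so a single step is only a weak guide. A modest move towards weaker inhibition is therefore expected, with a wide margin. In this assay the estimated change is a 2.5-fold higher number from compound 2 to compound 4 (0.40 log units; beyond the scatter) and it may not clear the scatter by much. Compound 4 is thus estimated at 60 nM with 15 nM to 240 nM as the expected range for the measurement.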

Compound 4, half-maximal inhibitory concentration: 44 nM
Compound 4: middle estimate off by 1.4-fold (0.13 log units), on the high side; low and high end bracket the measured number.
By their numbers in this assay, from the lowest: compounds 2, 1 and 4 (each within the scatter of the next); then compound 3.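

In this assay, putting 1-aminocyclopentyl in place of methyl on a carbonyl carbon, whose other neighbour is an amide-type nitrogen in a ring, gives a 1.8-fold higher number from compound 2 to compound 4 (0.26 log units; within the scatter), so the two cannot be ranked. This position therefore accepts a group of 6 heavy atoms, carrying a five-membered ring and a hydrogen-bond donor, in place of a methyl of 1 heavy atom, with no difference that stands clear of the scatter, whereas the earlier hydroxy step on this carbonyl side chain, made on a different core, gave a 3.8-fold higher number from compound 1 to compound 3 (0.58 log units; beyond the scatter). Nothing measured here offers an explanation for this tolerance.

The compounds shown leave open whether the ring or the amine matters more here, since 1-aminocyclopentyl brings both onto the carbonyl carbon at once. A plain cyclopentyl group without the amine and an open-chain aminomethyl group at the same place would pull those two parts apart, and each could then be set directly against compound 2 and compound 4.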